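A few compounds are considered here, and "the series" means these few. Any claim that something is new, unique, unknown or untested is made for them only; others in the source may bear on it.

Among the measured compounds shown here, in a functional assay on MCF7 cells (Homo sapiens) for cytotoxicity, read by MTT assay, with a stated time of 72 h (on this read-out higher numbers stand for weaker inhibition and lower numbers for stronger inhibition), two compounds with closely related structures have values so far. Compound 1 (`COC(=O)c1sc2c(C)cccc2c1Nc1cc(OC)c(OC)c(OC)c1`) gives 4550 nM and compound 2 (`CCOC(=O)c1sc2ccccc2c1Nc1cc(OC)c(OC)c(OC)c1`) gives 6390 nM so the two stand within the scatter of each other. Compound 3 (`CCOC(=O)c1sc2cccc(C)c2c1Nc1cc(OC)c(OC)c(OC)c1`) departs from compound 2 in one place: methyl in place of hydrogen on an aromatic carbon with methyl in place of hydrogen on an aromatic carbon. For the measured compounds named here, no measured pair shows this change on its own. Compound 1 also carries a methyl on an aromatic carbon, but it differs from compound 2 in more than that, and compound 1 at 4550 nM offers only weak guidance. The estimated step of a 1.4-fold lower number from compound 2 to compound 3 (0.15 log units; within the scatter) is therefore expected to stay within the scatter, with no clear change in either direction. For compound 3 the estimated value is 4500 nM (expected range 1000 nM to 15000 nM).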

Compound 3, half-maximal inhibitory concentration: 4150 nM
For compound 3 the middle estimate is 1.1-fold (0.04 log units) above the measured one; low and high end bracket the measured number.
By their numbers in this assay, from the lowest: compounds 3, 1 and 2 (each within the scatter of the next).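

In this assay, among the compounds shown here, the change of methyl in place of hydrogen on an aromatic carbon, ortho to a fused ring and meta to a fused ring, gives a 1.5-fold lower number from compound 2 to compound 3 (0.19 log units; within the scatter), the first reading of this change on its own. Compound 1 also carries a methyl on an aromatic carbon but differs from compound 2 in more than that, whereas this pair shows that a methyl at this place brings no clear shift in either direction. Nothing measured here accounts for this result.

The compounds shown leave open whether a methoxy group, a chlorine atom, an amine or a longer chain such as propyl on this same carbon would move the number beyond the scatter. They also leave open how a methyl would read on the other carbons of this ring, with the rest of compound 3 unchanged.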